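The source may report more compounds than this note shows. Statements on the series, on what has been measured and on what is new or still open speak of the compounds shown alone.

Measured so far:
compound 1, `CN(C)CCCCCSC1=Nc2ccccc2C(CC(=O)NCc2ccccc2)N1c1ccc(-c2ccc(F)cc2)cc1`, 9200 nM
compound 2, `CN(C)CCCCCSC1=Nc2ccccc2C(CC(=O)NCc2ccc(F)cc2)N1c1ccccc1`, 38800 nM
compound 3, `CN(C)CCCCCSC1=Nc2ccccc2C(CC(=O)NCc2ccccc2)N1c1ccccc1`, 38800 nM

In a functional assay on HCT-116 cells (Homo sapiens) for cytotoxicity, read by MTT assay, with a stated time of 48 h (a lower number here means a stronger inhibitor, a higher number a weaker inhibitor), compound 3 gives 38800 nM and compound 2 gives 38800 nM, the two standing level at the digits reported; the difference between their cores is fluoro in place of hydrogen on an aromatic carbon. Compound 1 gives 9200 nM. For the measured compounds named here, the one step that moves the read-out is a 4.2-fold lower number from compound 3 to compound 1 (0.63 log units; beyond the scatter), whereas no change at the digits printed from compound 2 to compound 3 (within the scatter).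

Compound 4, `CN(C)CCCCCSC1=Nc2ccccc2C(CC(=O)NCc2ccc(F)cc2)N1c1ccc(-c2ccc(F)cc2)cc1`, is not yet measured. It differs from compound 2 by 4-fluorophenyl in place of hydrogen on an aromatic carbon, and compound 1 differs from compound 3 by 4-fluorophenyl in place of hydrogen on an aromatic carbon; the two changes are the same, down to the place described, so this change has been seen once before.

Going by the values given here, for compound 4 in this assay the step expected is a 4.1-fold lower number from compound 2 to compound 4 (0.61 log units; beyond the scatter), resting on the single earlier instance because a 4.2-fold lower number from compound 3 to compound 1 (0.63 log units; beyond the scatter), taken together with compound 2 at 38800 nM. One earlier case is a thin basis, so the range is kept wide. The estimate for compound 4 is 9500 nM, expected between 4000 nM and 25000 nM.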

Compound 4, half-maximal inhibitory concentration: 9300 nM
Estimate against measurement, compound 4: 1.0-fold (0.01 log units) above; the range from low to high includes it.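

In this assay, 4-fluorophenyl in place of hydrogen gives a 4.2-fold lower number from compound 2 to compound 4 (0.62 log units; beyond the scatter), and the step carries over in full from the core without the second fluoro to the core that has it: the same change on two cores in this assay, a 4.2-fold lower number (0.63 log units; beyond the scatter) from compound 3 to compound 1 and a 4.2-fold lower number (0.62 log units; beyond the scatter) from compound 2 to compound 4, 1.0-fold (0.00 log units) apart, within the scatter of two such steps. Fluoro in place of hydrogen gives a 1.0-fold higher number from compound 1 to compound 4 (0.00 log units; within the scatter), and it is just as silent whether or not the 4-fluorophenyl is present: the same change on two cores in this assay, no change at the digits printed (within the scatter) from compound 2 to compound 3 and a 1.0-fold lower number (0.00 log units; within the scatter) from compound 4 to compound 1, 1.0-fold (0.00 log units) apart, within the scatter of two such steps. Within these four compounds the two changes therefore behave independently, but the two cores differ only by that one fluoro, so the match shows nothing about transfer to a core that differs more widely, and it gives no reason for the size of the step.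

As far as these compounds go, it remains open how a plain phenyl, a chloro or a methoxy at the same place would compare with 4-fluorophenyl. From the compounds shown here alone, it is also open whether the step would hold with a shorter chain, or with a morpholine in place of the dimethylamino group.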